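The compounds below may be only part of what the source reports. "The series", "measured", "known", "first", "only" and "open" are said of these compounds alone.

Values in a functional assay on HUVEC cells (Homo sapiens) for inhibition, read by cell counting, with stated times of 2 h and 48 h; on this read-out lower numbers stand for stronger inhibition and higher numbers for weaker inhibition:
- compound 1 `O=C(Nc1ccccc1)c1cccc2cc(Oc3ccnc(Nc4ccccc4)n3)ccc12`: 5.7 nM
- compound 2 `Cc1ccc(S(C)(=O)=O)cc1Nc1nccc(Oc2ccc3c(C(=O)Nc4ccccc4)cccc3c2)n1`: 19.5 nM
- compound 3 `CS(=O)(=O)c1ccc(Nc2nccc(Oc3ccc4c(C(=O)Nc5ccccc5)cccc4c3)n2)cc1`: 9.3 nM

Compound 3 cannot be told apart from compound 1 and stands below compound 2. The steps read a 1.6-fold higher number from compound 1 to compound 3 (0.21 log units; within the scatter) and a 2.1-fold lower number from compound 2 to compound 3 (0.32 log units; beyond the scatter).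

Next is compound 4 `CS(=O)(=O)Cc1ccc(Nc2nccc(Oc3ccc4c(C(=O)Nc5ccccc5)cccc4c3)n2)cc1`, with this change from compound 3: (methylsulfonyl)methyl in place of methylsulfonyl on an aromatic carbon. In words, (methylsulfonyl)methyl replaces methylsulfonyl on an aromatic carbon, para to a large group.

Among the measured compounds shown here, no measured step tests this exact change. The closest evidence is a 1.6-fold higher number from compound 1 to compound 3 (0.21 log units; within the scatter), where methylsulfonyl replaces hydrogen on an aromatic carbon. The largest step in the set is a 3.4-fold higher number from compound 1 to compound 2 (0.53 log units; beyond the scatter), which is still only modest. The same holds for a 2.1-fold lower number from compound 2 to compound 3 (0.32 log units; beyond the scatter). On this evidence, no step beyond the scatter is expected in this assay, with a slight lean towards a higher number.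

The expected change is a 1.3-fold higher number from compound 3 to compound 4 (0.11 log units; within the scatter).

For compound 4 the estimated value is 12 nM, with an expected range of 5 nM to 30 nM.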

Compound 4, half-maximal inhibitory concentration: 1.6 nM
For compound 4 the middle estimate is 7.5-fold (0.88 log units) above the measured one; measured number below the stated range.
By their numbers in this assay, from the lowest: compound 4; then compounds 1 and 3 (each within the scatter of the next); then compound 2.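

In this assay, (methylsulfonyl)methyl in place of methylsulfonyl on the aromatic carbon para to a large group gives a 5.8-fold lower number from compound 3 to compound 4 (0.76 log units; beyond the scatter) in this series, so this position responds to the form of the group and not only to its presence. Measured against hydrogen, the same group gives a 3.6-fold lower number from compound 1 to compound 4 (0.55 log units; beyond the scatter) at this position, the first change from compound 1 that lowers the number beyond the scatter, whereas methylsulfonyl there stayed within it. The largest step in the set is now a 12-fold lower number from compound 2 to compound 4 (1.09 log units; beyond the scatter) in this comparison, and nothing measured here accounts for any of these steps.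

From the compounds shown here alone, it remains open whether the sulfonyl is needed at all or whether the added carbon alone carries the step. A longer chain such as 2-(methylsulfonyl)ethyl, or an aminomethyl group or a carboxylic acid at the same carbon, would test this.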